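Bromo to methyl on the shared core of compound 3

The compounds below may be only part of what the source reports. "The series", "measured", "known", "first", "only" and "open" are said of these compounds alone.

Three compounds have been measured in an assay for binding affinity to adenosine receptor A1 (Bos taurus); a higher number here means a weaker inhibitor, a lower number a stronger inhibitor:
compound 1 `CCn1c(=O)c2nc(-c3ccc(S(=O)(=O)N4CCOCC4)cc3)[nH]c2n(CC)c1=O` gives 13 nM;
compound 2 `Cc1cccc(-c2nc3c(=O)n(C)c(=O)n(C)c3[nH]2)c1` gives 13 nM;
compound 3 `Cn1c(=O)c2nc(-c3ccc(Br)cc3)[nH]c2n(C)c1=O` gives 0.75 nM.

Compound 3 stands lowest of the three numbers; the values of compound 1 and compound 2 both lie well beyond the scatter above it, so compound 3 is the strongest of the measured set. Compound 4 `Cc1ccc(-c2nc3c(=O)n(C)c(=O)n(C)c3[nH]2)cc1` is not yet measured in this assay and differs from compound 3 in one place: methyl in place of bromo on an aromatic carbon. Among the compounds with values here, no measured pair shows this particular change on this core, so its size rests on indirect evidence. Some loss seems plausible because compound 2, which also carries a methyl on its aromatic ring, gives 13 nM in this assay. The expected step in this assay is therefore an 8.0-fold higher number from compound 3 to compound 4 (0.90 log units; beyond the scatter). Compound 4 is estimated at 6 nM, with a range from 2 nM to 20 nM.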

Compound 4, half-maximal inhibitory concentration: 0.8 nM
Compound 4: middle estimate off by 7.5-fold (0.88 log units), on the high side, and the stated range ends above it.
By their numbers in this assay, from the lowest: compounds 3 and 4 (each within the scatter of the next); then compounds 1 and 2 (each within the scatter of the next).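

In this assay, methyl in place of bromo on an aromatic carbon, para to a large group, gives a 1.1-fold higher number from compound 3 to compound 4 (0.03 log units; within the scatter), so on this core the two groups cannot be told apart at this position. Compound 4 carries a methyl on its aromatic ring, as compound 2 does, yet compound 4 gives 0.8 nM while compound 2 gives 13 nM, which shows that such a methyl does not by itself bring the higher number. Nothing available here explains why bromo and methyl read alike at this position.

The compounds shown leave open whether the number at this position would hold with an amine, a carboxylic acid or a longer chain in place of the methyl. They also leave open whether bromo and methyl would read alike on the core of compound 1.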